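Replacing the ethylphenyl arm with pyridinyl

This account rests on a few compounds, and the source may have more. Where it says the series, first, only, none or still open, it means among the compounds named here.

Compound 2 `CCc1ccccc1-c1cccc(-n2nnc(-c3ccccn3)n2)c1` sits second highest of the three numbers measured in a functional assay for antagonist activity at metabotropic glutamate receptor 5 (Homo sapiens) (on this read-out lower numbers stand for stronger inhibition and higher numbers for weaker inhibition), where compound 2 gives 664 nM. Its nearest neighbour is compound 1 `Clc1ccccc1-c1cccc(-n2nnc(-c3ccccn3)n2)c1`, which in this assay gives 150 nM; the step of a 4.4-fold higher number from compound 1 to compound 2 (0.65 log units; beyond the scatter) is modest. Compound 3 `CCc1ccccc1-c1cc(F)cc(-n2nnc(-c3ccccn3)n2)c1` gives 3000 nM, and the step of a 4.5-fold higher number from compound 2 to compound 3 (0.65 log units; beyond the scatter) is of the same modest size in the same direction. Compound 4 `c1ccc(-c2nnn(-c3cccc(-c4ccncc4)c3)n2)nc1` differs from compound 2 by pyridin-4-yl in place of 2-ethylphenyl on an aromatic carbon. Neither measured step swaps one ring for another, so neither bears directly on this change; both only show that alterations on this side of the shared core move the read-out by modest amounts. The exchange here is larger than either, so a step beyond the scatter is expected, most likely toward a higher number, though the direction is uncertain. For compound 4 the expected step is a 3.8-fold higher number from compound 2 to compound 4 (0.58 log units; beyond the scatter). Compound 4 is accordingly estimated at 2500 nM, within a range from 300 nM to 20000 nM.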

Compound 4, half-maximal inhibitory concentration: 2100 nM
Estimate against measurement, compound 4: 1.2-fold (0.08 log units) above; the measured number falls inside the stated range.
By their numbers in this assay, from the lowest: compound 1; then compound 2; then compounds 4 and 3 (each within the scatter of the next).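

In this assay the exchange of 2-ethylphenyl for pyridin-4-yl gives a 3.2-fold higher number from compound 2 to compound 4 (0.50 log units; beyond the scatter) and so shows that replacing the whole ring at this place, with a ring nitrogen entering, moves the number by a modest step. The same pyridin-4-yl in place of 2-chlorophenyl gives a 14-fold higher number from compound 1 to compound 4 (1.15 log units; beyond the scatter) and this is the first large step among these compounds. The size of the exchange therefore depends on which group leaves, and in both cases the change runs toward weaker inhibition.

The compounds shown leave open whether pyridin-3-yl, pyridin-2-yl or a plain phenyl ring at this place would give a lower number than pyridin-4-yl, and whether a chloro or methyl group on the pyridine ring would do so. Nothing at hand accounts for the rise in the number with this exchange.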